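A few compounds are considered here, and "the series" means these few. Any claim that something is new, unique, unknown or untested is made for them only; others in the source may bear on it.

Compound 1 `C=CC1=C(C(=O)NCCCCC)C(c2ccc(OC)cc2)OC1` in a functional assay on HeLa cells (Homo sapiens) for cytotoxicity, read by MTT assay, with a stated time of 24 h (on this read-out higher numbers stand for weaker inhibition and lower numbers for stronger inhibition), gives only a limit, > 100000 nM. Among the compounds with values here, compound 2 `C=CC1=C(C(=O)NC2CCCCC2)C(c2ccc(OC)cc2)OC1` gives 24800 nM, the only number so far in this assay. The remaining value is the limit of > 100000 nM in this assay, at which 1 of the 2 values shown sits. Within the data shown here, the single measured step, an at least 4.0-fold lower number from compound 1 to compound 2 (0.60 log units; beyond the scatter), came from cyclohexyl in place of pentyl on an amide-type nitrogen. Compound 3 `C=CC1=C(C(=O)NCc2ccc(C)cc2)C(c2ccc(OC)cc2)OC1` carries the change (4-methylbenzyl in place of cyclohexyl on an amide-type nitrogen). That measured step concerns the same nitrogen but different groups, so it gives little guide; no step beyond the scatter is expected in this assay, a 1.0-fold higher number from compound 2 to compound 3 (0.00 log units; within the scatter). Compound 3 is estimated at 25000 nM in this assay, within 8000 nM to 80000 nM.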

Compound 3, half-maximal inhibitory concentration: 15900 nM
Beside the measured number, compound 3's estimate is 1.6-fold (0.20 log units) above it; measured number inside the range.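

In this assay, an aromatic ring on the amide-type nitrogen reads the same as a saturated one (a 1.6-fold lower number from compound 2 to compound 3 (0.19 log units; within the scatter)). The 4-methylbenzyl group also separates from the open pentyl chain (an at least 6.2-fold lower number from compound 1 to compound 3 (0.79 log units; beyond the scatter)), so both ring-bearing groups shown stand apart from pentyl. The size of that step stays a bound, because compound 1 is a limit: the limit of > 100000 nM in this assay, at which 1 of the 3 values shown sits.

Open, as far as these compounds go, is whether unsubstituted benzyl, 4-methoxybenzyl or a benzyl carrying an amine would shift the number beyond the scatter. Also open, from the compounds shown here alone, is how a longer chain between the nitrogen and the aromatic ring would read.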